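This account rests on a few compounds, and the source may have more. Where it says the series, first, only, none or still open, it means among the compounds named here.

Measured compounds in the series:
- compound 1, `CNc1nc(NC)nc(NC2(C#N)CCCCC2)n1`: 210 mL/min/kg
- compound 2, `CNc1nc(NC2(C#N)CCCCC2)nc(OC)n1`: 196 mL/min/kg

In an ADME assay on microsomes from liver (Rattus norvegicus) for metabolic stability (a lower number here means slower removal, a higher number faster removal of the compound), compound 2 gives 196 mL/min/kg, and compound 1 gives 210 mL/min/kg. The two numbers sit within the scatter of each other, as the step of a 1.1-fold lower number from compound 1 to compound 2 (0.03 log units; within the scatter) shows; neither compound can be ranked against the other on this read-out, and both are cleared quickly.

Compound 3, `CNc1nc(NC2(C#N)CCCCC2)nc(-n2cnc(C#N)n2)n1`, is not yet measured. It differs from compound 2 in one place: 3-cyano-1H-1,2,4-triazol-1-yl in place of methoxy on an aromatic carbon. For the measured compounds named here, the only measured step, from compound 1 to compound 2, exchanges a methylamino group for a methoxy group at the same position and is within the scatter. Going by the values given here, no measured step exchanges a methoxy group for a 3-cyano-1H-1,2,4-triazol-1-yl group, so nothing in the data bears directly on the change to compound 3. The working expectation is therefore that compound 3 stays close to compound 2, with the step of a 1.2-fold lower number from compound 2 to compound 3 (0.06 log units; within the scatter) expected to lie within the scatter, though the range is kept wide for a change of this size. For compound 3 the estimate is 170 mL/min/kg, expected to fall between 80 mL/min/kg and 360 mL/min/kg.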

Compound 3, clearance: 210 mL/min/kg
Estimate against measurement, compound 3: 1.2-fold (0.09 log units) below; low and high end bracket the measured number.
By their numbers in this assay, from the lowest: compounds 2, 1 and 3 (each within the scatter of the next).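

In this assay, the aromatic carbon between two ring nitrogen atoms now carries a group with one five-membered aromatic ring and a triple bond, and the read-out stays within the scatter: the exchange for methoxy gives a 1.1-fold higher number from compound 2 to compound 3 (0.03 log units; within the scatter), and the exchange for methylamino gives no change at the digits printed from compound 1 to compound 3 (within the scatter). For the compounds shown here, the earlier pair covered only two small groups, so methylamino, methoxy and 3-cyano-1H-1,2,4-triazol-1-yl can now be set side by side at this position, and none of the three can be ranked against the others on this read-out. Nothing available explains this lack of separation or shows where on these compounds the removal takes place.

The compounds shown leave open whether any group on this carbon can move the number beyond the scatter, for example a carboxylic acid or a primary amine. They also leave open what a change elsewhere would do, since the methylamino group and the group of 9 heavy atoms stay the same across compound 2 and compound 3, for example a hydroxyl on that group of 9 heavy atoms.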